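A larger group on the sulfur of compound 3

The compounds below may be only part of what the source reports. "The series", "measured", "known", "first", "only" and "open" are said of these compounds alone.

Measured in a functional assay on NCI-H1975 cells (Homo sapiens) for inhibition, read by MTT assay, with a stated time of 72 h; on this read-out higher numbers stand for weaker inhibition and lower numbers for stronger inhibition:
- compound 1 `FC(F)(F)c1ccc(CSc2nc(N3CCN(c4ccccc4)CC3)cc(C(F)(F)F)n2)cc1`: > 50000 nM (a limit, not a number)
- compound 2 `FC(F)(F)c1ccc(CSc2nc(N3CCN(c4ncccn4)CC3)cc(C(F)(F)F)n2)cc1`: 18300 nM
- compound 3 `Cc1csc(Sc2cc(C(F)(F)F)nc(SCc3ccc(C(F)(F)F)cc3)n2)n1`: 5840 nM

In this assay compound 2 gives 18300 nM and compound 3 gives 5840 nM, so compound 3 holds the lower of the two numbers. The value of compound 1 is a limit.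

The next compound, compound 4 `FC(F)(F)c1ccc(CSc2nc(Sc3ncc(-c4ccncc4)s3)cc(C(F)(F)F)n2)cc1`, keeps the shared core and differs from compound 3 in one group: 5-(pyridin-4-yl)-1,3-thiazol-2-yl in place of 4-methyl-1,3-thiazol-2-yl on a sulfur. In words, 5-(pyridin-4-yl)-1,3-thiazol-2-yl stands in place of 4-methyl-1,3-thiazol-2-yl on a sulfur.

Going by the values given here, only one measured step offers guidance: an at least 2.7-fold lower number from compound 1 to compound 2 (0.43 log units; beyond the scatter), with pyrimidin-2-yl in place of phenyl on an amine nitrogen in a ring. That step lies at a different place and rests on a limit, so it bears only loosely on this change. Its direction was towards a lower number, and a small step in that same direction is expected in this assay, perhaps no larger than the scatter. The estimated step is a 1.9-fold lower number from compound 3 to compound 4 (0.29 log units; within the scatter). For compound 4 the estimate is 3000 nM, with an expected range from 800 nM to 12000 nM.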

Compound 4, half-maximal inhibitory concentration: 16700 nM
Beside the measured number, compound 4's estimate is 5.6-fold (0.75 log units) below it, outside the stated range (above it).
By their numbers in this assay, from the lowest: compound 3; then compounds 4 and 2 (each within the scatter of the next). At a limit, above all of these: compound 1.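

In this assay, the group on this sulfur turns out not to be a neutral place for change: 5-(pyridin-4-yl)-1,3-thiazol-2-yl in place of 4-methyl-1,3-thiazol-2-yl gives a 2.9-fold higher number from compound 3 to compound 4 (0.46 log units; beyond the scatter), which means weaker inhibition. Going by these compounds alone, the only earlier step lay at a different place, on an amine nitrogen in a ring, and ran towards a lower number, so this is the first reading of this sulfur position, and it shows that a larger group carrying a second aromatic ring, a six-membered one with 1 hetero atom, does not improve on the small 4-methyl-1,3-thiazol-2-yl group here. Nothing in the data at hand gives a reason for this rise in the number.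

The compounds shown leave open whether the higher number goes with the added pyridin-4-yl ring itself or with the loss of the 4-methyl group, since the two changes arrive together in this one step. A 5-methyl-1,3-thiazol-2-yl or a 5-phenyl-1,3-thiazol-2-yl group on the same sulfur would begin to separate these two changes.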